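The compounds below may be only part of what the source reports. "The series", "measured", "known", "first", "only" and "open" are said of these compounds alone.

This study covers three related compounds, all sharing the same core, and tests them in a functional assay on NCI-H1792 cells (Homo sapiens) for cytotoxicity, read by resazurin assay, with a stated time of 72 h; a lower number here means a stronger inhibitor, a higher number a weaker inhibitor. Among the measured compounds shown here, compound 1, with the structure `COc1cc(/C=C/C(=O)OCCCCCO[N+](=O)[O-])ccc1O`, is the one with a clear number: in this assay compound 1 gives 13000 nM. Compound 2, with the structure `COc1cc(/C=C/C(=O)OCCCCCCO[N+](=O)[O-])ccc1OCCCCCCO[N+](=O)[O-]`, carries a 6-(nitrooxy)hexyl group on an oxygen on the aromatic ring. For compound 2 the reading in this assay is > 50000 nM, which is a limit of the assay rather than a number, as the limit of > 50000 nM in this assay, at which 1 of the 2 values shown sits, records. Compound 2 thus stands at the weak end of what has been measured.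

Compound 3, with the structure `COc1cc(/C=C/C(=O)OCCCCCCO[N+](=O)[O-])ccc1O`, has not yet been measured. It differs from compound 2 in one place: hydrogen in place of 6-(nitrooxy)hexyl on an oxygen on an aromatic ring.

Since the side with the free hydroxy is what compound 1 also has, and compound 1 gives 13000 nM, the expected step in this assay from compound 2 to compound 3 is an at least 3.8-fold lower number from compound 2 to compound 3 (0.58 log units; beyond the scatter), that is, towards stronger inhibition. The estimate for compound 3 in this assay is 13000 nM, with a range from 5000 nM to 40000 nM.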

Compound 3, half-maximal inhibitory concentration: 48700 nM
Compound 3: the middle estimate sits 3.7-fold (0.57 log units) below what was measured; the measured number lies above the stated range.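

Taking the 6-(nitrooxy)hexyl group off the oxygen on the aromatic ring, leaving a hydroxy there, produces no readable gain in this assay, where the step reads an at least 1.0-fold lower number from compound 2 to compound 3 (0.01 log units; that floor lies within the scatter). A free hydroxy on that oxygen is therefore not enough on its own to give a number like that of compound 1, and the ester chain also counts: with (nitrooxy)methyl in place of nitrooxy on a saturated chain carbon, five bonds along the chain from an oxygen next to a carbonyl group, the result is a 3.7-fold higher number from compound 1 to compound 3 (0.57 log units; beyond the scatter), a clear move towards weaker inhibition from a small change. Going by these compounds, compound 2 has a limit of the assay rather than a number, so the true size of the step from its side remains unknown, and it could be larger than this floor: the limit of > 50000 nM in this assay, at which 1 of the 3 values shown sits.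

On these data alone, whether the rise in the number continues with a longer chain on the ester, or reverses with a shorter one, remains open. So does the effect of an amine or a carboxylic acid at the end of that chain in place of the nitrooxy group.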